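Thiazole for Thiadiazole on the Ring Amide Nitrogen

This account rests on a few compounds, and the source may have more. Where it says the series, first, only, none or still open, it means among the compounds named here.

Compound 1, `Cc1noc(C)c1-c1ccc2c(c1)C(c1ccccc1)NC(=O)N2C`, gives 27.8% in a functional assay on HCT-116 cells (Homo sapiens) for inhibition, read by MTT assay, with a stated time of 48 h, tested at 2 uM; on this read-out higher numbers stand for more inhibition at the one concentration tested (going by the name of the read-out) and lower numbers for less inhibition.
Compound 2, `Cc1noc(C)c1-c1ccc2c(c1)C(c1ccccc1)N(Cc1nnc(-c3ccccc3)s1)C(=O)N2C`, gives 26.9% in this assay.

Going by the values given here, compound 2 holds the lower of the two numbers measured so far, but its nearest neighbour is compound 1, and the only measured step, a number 0.9 percentage points lower from compound 1 to compound 2 (within the scatter), lies within the scatter, so the two compounds cannot be told apart on this read-out.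

Compound 3, `Cc1noc(C)c1-c1ccc2c(c1)C(c1ccccc1)N(Cc1nc(-c3ccccc3)cs1)C(=O)N2C`, keeps everything of compound 2 except the aromatic group on the chain carbon: 4-phenyl-1,3-thiazol-2-yl in place of 5-phenyl-1,3,4-thiadiazol-2-yl on a saturated chain carbon bound to an amide-type nitrogen in a ring.

Among the compounds with values here, no measured step bears on this change directly. Within the data shown here, the single step available, a number 0.9 percentage points lower from compound 1 to compound 2 (within the scatter), shows that adding the whole (5-phenyl-1,3,4-thiadiazol-2-yl)methyl group to the amide-type nitrogen left the read-out in this assay unchanged beyond the scatter. Exchanging one five-membered aromatic ring for a closely related one within that same group is therefore expected to move the number no more than the scatter; the expected step is a number 0.1 percentage points higher from compound 2 to compound 3 (within the scatter).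

Compound 3 is thus estimated at 27%, with a range from 12% to 42%.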

Compound 3, a percentage reported as inhibition, at one concentration (the size of the read-out at that concentration, not a potency): 26.7%
Compound 3: the middle estimate sits 0.3 percentage points above what was measured, within the range that was stated.
By their numbers in this assay, from the lowest: compounds 3, 2 and 1 (each within the scatter of the next).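

In this assay, the exchange of a five-membered aromatic ring with 3 hetero atoms for one with 2 hetero atoms, with the phenyl ring kept, gives a number 0.2 percentage points lower from compound 2 to compound 3 (within the scatter), so this change on a saturated chain carbon bound to an amide-type nitrogen in a ring leaves the two compounds indistinguishable. The comparison with the parent, which carries hydrogen on that nitrogen, gives a number 1.1 percentage points lower from compound 1 to compound 3 (within the scatter), which means that a second large aromatic group, not only the (5-phenyl-1,3,4-thiadiazol-2-yl)methyl group, can stand at this nitrogen without a difference that this read-out can resolve. No supporting measurement is available to explain why these three compounds cannot be told apart.

The compounds shown leave open whether an amine or a carboxylic acid in place of the phenyl ring on the thiazole, or a longer chain in place of the methyl link, would separate from the parent in this assay. They also leave open whether compounds that match at this single concentration would still match across a range of concentrations.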